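A few compounds are considered here, and "the series" means these few. Any claim that something is new, unique, unknown or untested is made for them only; others in the source may bear on it.

In a functional assay on HepG2 cells (Homo sapiens) for cytotoxicity, read by MTT assay, with a stated time of 48 h (on this read-out higher numbers stand for weaker inhibition and lower numbers for stronger inhibition), compound 3 `O=C(CSc1nnc(-c2ccncc2)o1)N/N=C/c1ccccc1F` gives 16000 nM. Compound 1 `O=C(CSc1nnc(-c2ccncc2)o1)N/N=C/c1ccccc1` gives 17300 nM and compound 2 `O=C(CSc1nnc(-c2ccncc2)o1)N/N=C/c1ccc([N+](=O)[O-])cc1` gives 17900 nM, and both lie within the scatter of compound 3, so no order can be read among the three. Compound 4 `COc1cc(/C=N/NC(=O)CSc2nnc(-c3ccncc3)o2)ccc1O` is not yet measured; the change from compound 3 is 4-hydroxy-3-methoxyphenyl in place of 2-fluorophenyl on a carbon with a double bond to nitrogen. Among the measured compounds shown here, the steps that bear on it, a 1.1-fold lower number from compound 1 to compound 3 (0.03 log units; within the scatter) and a 1.1-fold lower number from compound 2 to compound 3 (0.05 log units; within the scatter), were both within the scatter, as was a 1.0-fold higher number from compound 1 to compound 2 (0.01 log units; within the scatter): no exchange on this ring has yet moved this assay beyond it. For the measured compounds named here, the entering ring has no measured counterpart, so the expected step of a 1.1-fold higher number from compound 3 to compound 4 (0.03 log units; within the scatter) is none beyond the scatter. Compound 4 is therefore estimated at 17000 nM, with a range from 8000 nM to 36000 nM.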

Compound 4, half-maximal inhibitory concentration: 2920 nM
For compound 4 the middle estimate is 5.8-fold (0.77 log units) above the measured one; measured number outside the range, below it.
By their numbers in this assay, from the lowest: compound 4; then compounds 3, 1 and 2 (each within the scatter of the next).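

In this assay, the place on a carbon with a double bond to nitrogen can move the number beyond the scatter, with 4-hydroxy-3-methoxyphenyl entering in place of 2-fluorophenyl (a 5.5-fold lower number from compound 3 to compound 4 (0.74 log units; beyond the scatter)), 4-nitrophenyl (a 6.1-fold lower number from compound 2 to compound 4 (0.79 log units; beyond the scatter)) and phenyl (a 5.9-fold lower number from compound 1 to compound 4 (0.77 log units; beyond the scatter)). The earlier nitro and fluoro exchanges on this ring had not done so. No measurement bears on what lies behind this change.

From the compounds shown here alone, whether the hydroxy or the methoxy group alone would give such a step remains open. So does the outcome with an amine or a carboxylic acid on this ring.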